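Notes on N-substituted beta-lactam carbamates as acid amidase inhibitors

The compounds below may be only part of what the source reports. "The series", "measured", "known", "first", "only" and "open" are said of these compounds alone.

Measured compounds:
compound 1, `CN1C[C@H](NC(=O)OCCCCC2CCCCC2)C1=O`, in an assay on HEK293 cells for inhibition of N-acylethanolamine-hydrolyzing acid amidase (Homo sapiens), read by fluorescence, with stated times of 10 min and 50 min (a lower number here means a stronger inhibitor, a higher number a weaker inhibitor), compound 1 gives 1980 nM.
compound 2, `CCCCCON1C(=O)[C@@H](NC(=O)OCCCCC2CCCCC2)[C@@H]1C`, in this assay compound 2 gives 387 nM.

Of the two numbers in hand, compound 2 holds the lower one; compound 1 sits higher, and the gap between compound 1 and compound 2 lies beyond the scatter. The two compounds differ in more than one place, so the figures for compound 1 and compound 2 only show where each stands, not what any single change is worth.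

Compound 3, `C[C@H]1[C@H](NC(=O)OCCCCC2CCCCC2)C(=O)N1Oc1ccc([N+](=O)[O-])cc1`, keeps the core and the carbamate chain of compound 2 and changes only the group on the ring-nitrogen oxygen: 4-nitrophenyl in place of pentyl on an oxygen. Among the compounds with values here, no measured pair in this set isolates a change of that kind on that oxygen, so there is no direct precedent for its size or direction.

The working expectation is a small step, at most on the edge of the scatter, expressed as a 1.5-fold lower number from compound 2 to compound 3 (0.19 log units; within the scatter). Compound 3 is therefore estimated at 250 nM, with a range from 60 nM to 1500 nM.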

Compound 3, half-maximal inhibitory concentration: 17 nM
Beside the measured number, compound 3's estimate is 15-fold (1.17 log units) above it; the measured number lies below the stated range.
By their numbers in this assay, from the lowest: compound 3; then compound 2; then compound 1.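

The oxygen on the ring's amide-type nitrogen proves to be a sensitive place in this assay: with the core and carbamate chain held constant, 4-nitrophenyl in place of pentyl gives a 23-fold lower number from compound 2 to compound 3 (1.36 log units; beyond the scatter). Within the data shown here, this is the only single-place change so far, and it shows that the group on this oxygen can by itself move the number well beyond the scatter, which the comparison of compound 1 with compound 2 could not show. The finding rests on this one pair, and no measurement in hand accounts for the size of the step.

On these data alone, it remains open whether the step depends on the aromatic ring, the nitro group or both, a question that plain phenyl, 4-methoxyphenyl or benzyl on the same oxygen would help to separate. As far as these compounds go, it is also open whether an exchange of pentyl for 4-nitrophenyl would give a step of similar size with another carbamate chain, such as one ending in phenyl rather than cyclohexyl.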